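A few compounds are considered here, and "the series" means these few. Any claim that something is new, unique, unknown or untested is made for them only; others in the source may bear on it.

Measured compounds and their values in a functional assay on Huh-7 cells (Homo sapiens) for cytotoxicity, read by CCK-8 assay, with a stated time of 72 h; on this read-out lower numbers stand for stronger inhibition and higher numbers for weaker inhibition:
- compound 1 `C=CCn1c(=O)/c(=C\c2cccc(C)c2)[nH]c(=O)/c1=C\c1ccccc1OC`: 21400 nM
- compound 2 `COc1ccccc1/C=c1/[nH]c(=O)/c(=C\c2ccccc2OC)[nH]c1=O`: "not active" (no number reported)
- compound 3 `COc1ccccc1/C=c1\c(=O)[nH]/c(=C/c2cccc(Cl)c2Cl)c(=O)n1C`: 300 nM

Compound 3 gives the lowest number of the two that were reported in this assay; compound 1 sits far higher, a gap well beyond the scatter of repeated measurements, and compound 2 came back without a number, as not active. Compound 4 `COc1ccccc1/C=c1\c(=O)[nH]/c(=C/c2ccccc2Cl)c(=O)n1C` has not yet been measured. It differs from compound 3 in one place: hydrogen in place of chloro on an aromatic carbon. Cut one bond further out, the same difference reads 2,3-dichlorophenyl to 2-chlorophenyl. For the measured compounds named here, no pair of measured compounds differing only in this way exists here, so the size of the step can only be estimated. Losing one chloro group on that ring is a small change, and a moderate weakening is expected, of the order a 2.7-fold higher number from compound 3 to compound 4 (0.43 log units; beyond the scatter), though a result within the scatter would not be surprising. Compound 4 is therefore expected to give about 800 nM in this assay, with a plausible range from 250 nM to 3000 nM.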

Compound 4, half-maximal inhibitory concentration: 300 nM
The estimate for compound 4 lay 2.7-fold (0.43 log units) above the measured number, and the stated range covers the measured number.
By their numbers in this assay, from the lowest: compounds 3 and 4 (each within the scatter of the next); then compound 1.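

Putting hydrogen in place of chloro on this aromatic carbon gives no change at the digits printed from compound 3 to compound 4 (within the scatter) in this assay, so the 2,3-dichlorophenyl and 2-chlorophenyl compounds cannot be told apart on this read-out. For the compounds shown here, the earlier compounds differ from one another in more than one place, and this is the first direct reading of a single change on this ring: at this carbon, the chloro group can be exchanged for hydrogen with no measurable effect. The data offer no explanation for this result.

This single pair does not show whether the remaining chloro group on the ring matters as well. It also leaves open how an amine or a carboxylic acid on the same aromatic carbon would read in this assay, since only chloro and hydrogen have been compared there.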